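Butyl enamine curcuminoids: isobutyl against sec-butyl on nitrogen

The source may hold more compounds than are shown below. What is called first, only, known or untested is meant among the compounds shown, and "the series" means these compounds.

Compound 1 `CCC(C)NC(=C\C(=O)/C=C/c1ccc(O)c(OC)c1)/C=C/c1ccc(O)c(OC)c1` gives in an ADME assay on EA.hy 926 cells (Homo sapiens) for inhibition, read by sulforhodamine B assay, with a stated time of 72 h (a higher number here means a weaker inhibitor, a lower number a stronger inhibitor), only a limit, > 25000 nM.
Compound 2 `COc1cc(/C=C/C(=O)/C=C(/C=C/c2ccc(OC(C)=O)c(OC)c2)NCC(C)C)ccc1OC(C)=O` gives in this assay only a limit, > 25000 nM.
Compound 3 `COc1cc(/C=C/C(=O)/C=C(/C=C/c2ccc(O)c(OC)c2)NCC(C)C)ccc1O` gives in this assay only a limit, > 25000 nM.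

Compound 4 `CCC(C)NC(=C\C(=O)/C=C/c1ccc(OC(C)=O)c(OC)c1)/C=C/c1ccc(OC(C)=O)c(OC)c1` has not yet been measured in this assay.

Compound 3 and compound 1 differ by sec-butyl in place of isobutyl on an amine nitrogen. The resulting step that the two limits leave unreadable from compound 3 to compound 1 cannot be read, since both ends are limits. Compound 2 and compound 4 differ by sec-butyl in place of isobutyl on an amine nitrogen, the same change at the same place. The difference between the cores of compound 2 and compound 3 is not broken down here.

For the new pair the expected step that the limit leaves unreadable from compound 2 to compound 4 is set at no change, because the limit of > 25000 nM in this assay, at which 3 of the 3 values shown sit, leaves nothing else to rest on.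

Compound 4 is therefore expected to give 40000 nM, between 15000 nM and 200000 nM, most likely reported again only as a limit.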

Compound 4, half-maximal inhibitory concentration: > 25000 nM
Compound 4: no number, only a limit; the forecaster's own chance of this, stated with the estimate: 85%; the middle value is on the limit's open side.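

For the compounds shown here, compound 2 and compound 4 both stand only as limits in this assay, and no step between them can be read. On these data alone, whether sec-butyl in place of isobutyl on an amine nitrogen shifts inhibition at all stays open.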